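A few compounds are considered here, and "the series" means these few. Any claim that something is new, unique, unknown or untested is made for them only; others in the source may bear on it.

Measured so far in a functional assay on HEK293T cells for agonist activity at histamine H2 receptor (Homo sapiens), read by beta-arrestin recruitment; on this read-out lower numbers stand for an effect already at smaller amounts and higher numbers for an effect only at larger amounts of compound:
compound 1 `Cc1nc(N)sc1CCCN/C(N)=N/C(=O)N[C@H](C)c1ccccc1`, 45.7 nM
compound 2 `Cc1ccc(CC(C)CNC(=O)/N=C(\N)NCCCc2sc(N)nc2C)cc1`, 132 nM

Compound 1 stands at the lowest of the two numbers in this assay. Compound 2 sits at the higher number, and the gap between compound 1 and compound 2 lies beyond the usual scatter of this read-out.

Compound 3 `Cc1nc(N)sc1CCCN/C(N)=N/C(=O)NC(C)c1ccco1` has not yet been measured in this assay. Relative to compound 1 the change is 1-(furan-2-yl)ethyl in place of 1-phenylethyl on an amide-type nitrogen. For the measured compounds named here, no pair of measured compounds shows this kind of change, so nothing in the present numbers sets its size or direction; a step on the scale of the scatter, or none beyond it, is the working expectation, with a slight lean toward a higher number.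

Compound 3 is expected to give 65 nM in this assay, with a range of 25 nM to 170 nM. The step this estimate implies is expected to be a 1.4-fold higher number from compound 1 to compound 3 (0.15 log units; within the scatter).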

Compound 3, half-maximal effective concentration: 234 nM
Beside the measured number, compound 3's estimate is 3.6-fold (0.56 log units) below it; the measured number lies above the stated range.
By their numbers in this assay, from the lowest: compound 1; then compounds 2 and 3 (each within the scatter of the next).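

In this assay, the group on the amide-type nitrogen carrying the carbonyl carbon matters: 1-(furan-2-yl)ethyl in place of 1-phenylethyl gives a 5.1-fold higher number from compound 1 to compound 3 (0.71 log units; beyond the scatter) and so moves the number beyond the scatter. This change also leaves compound 3 without the defined stereocentre of compound 1, so the step combines a ring exchange with a difference in defined stereochemistry and cannot be assigned to either alone. Nothing measured here explains the step.

Still open, from the compounds shown here alone, is whether a single stereoisomer of compound 3 would show the same step from compound 1. Also open, going by these compounds, is whether the step follows the ring oxygen or the five-membered ring, which 1-(thiophen-2-yl)ethyl and 1-(pyridin-2-yl)ethyl groups on the same nitrogen could help separate.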